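Chloro on a Compound Standing at a Limit

The compounds below may be only part of what the source reports. "The series", "measured", "known", "first", "only" and "open" are said of these compounds alone.

Values in a functional assay on V79 cells (Cricetulus griseus) for cytotoxicity, read by colony formation; on this read-out higher numbers stand for weaker inhibition and lower numbers for stronger inhibition:
Compound 1 `NCC1CCN(c2c(F)cc3c(=O)c(C(=O)O)cn(C4CC4)c3c2Cl)C1`: 8 ug/mL
Compound 2 `CC1CN(c2c(F)cc3c(=O)c(C(=O)O)cn(C4CC4)c3c2Cl)CC(C)N1`: 140 ug/mL
Compound 3 `NC1CCCN(c2cc3c(cc2F)c(=O)c(C(=O)O)cn3C2CC2)C1`: > 500 ug/mL

Compound 3 gives > 500 ug/mL in this assay, which is a limit and not a number. Compound 4 `NC1CCCN(c2c(F)cc3c(=O)c(C(=O)O)cn(C4CC4)c3c2Cl)C1` has chloro in place of hydrogen on an aromatic carbon, ortho to the 3-aminopiperidin-1-yl group: chloro in place of hydrogen on an aromatic carbon. For the measured compounds named here, no measured step makes this exchange directly. Going by the values given here, compound 1 and compound 2 both carry the chloro, and the one measured step, an 18-fold higher number from compound 1 to compound 2 (1.24 log units; beyond the scatter), is large. Compound 1 at 8 ug/mL and compound 2 at 140 ug/mL therefore give only indirect support, but a large step to a lower number is expected in this assay. The expected change is an at least 12-fold lower number from compound 3 to compound 4 (1.09 log units; beyond the scatter). For compound 4 the estimate is 40 ug/mL, with an expected range from 8 ug/mL to 250 ug/mL.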

Compound 4, half-maximal inhibitory concentration: 24 ug/mL
For compound 4 the middle estimate is 1.7-fold (0.22 log units) above the measured one; the measured number falls inside the stated range.
By their numbers in this assay, from the lowest: compound 1; then compound 4; then compound 2. At a limit, above all of these: compound 3.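

Compound 4 gives the direct reading of chloro in place of hydrogen on an aromatic carbon, ortho to a 3-aminopiperidin-1-yl group, in this assay: an at least 20-fold lower number from compound 3 to compound 4 (1.31 log units; beyond the scatter). That size is only a lower bound, because compound 3 stands at a limit and not at a number: the limit of > 500 ug/mL in this assay, at which 1 of the 4 values shown sits.

Among the chloro compounds, 3-aminopiperidin-1-yl sits in the middle: a 5.8-fold lower number from compound 2 to compound 4 (0.77 log units; beyond the scatter) and a 3.0-fold higher number from compound 1 to compound 4 (0.48 log units; beyond the scatter).

The compounds shown leave open whether hydrogen in place of chloro would move compound 1 or compound 2 as far. They also leave open how a bromo, methyl or methoxy group on this carbon would compare with chloro.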